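The compounds below may be only part of what the source reports. "The series", "measured", "known", "first", "only" and "open" are said of these compounds alone.

Series notes. The shared core of compound 1 `CC1(C)[C@H]2CC[C@]1(C)N(Cc1cn(-c3ccccc3O)nn1)C(=O)C2` carries an aryl group on the aromatic nitrogen; compound 2 `COc1ccc(-n2cc(CN3C(=O)C[C@@H]4CC[C@@]3(C)C4(C)C)nn2)cc1` and compound 3 `CC1(C)[C@H]2CC[C@]1(C)N(Cc1cn(-c3cccc(O)c3)nn1)C(=O)C2` vary that aryl group. In a functional assay on PANC-1 cells (Homo sapiens) for inhibition, read by MTT assay, with a stated time of 24 h (on this read-out lower numbers stand for stronger inhibition and higher numbers for weaker inhibition), compound 1 gives 230 nM, compound 2 gives 330 nM and compound 3 gives 280 nM. Compound 3 stands second highest of the three numbers, yet every step among them lies within the scatter: a 1.2-fold higher number from compound 1 to compound 3 (0.09 log units; within the scatter) and a 1.2-fold lower number from compound 2 to compound 3 (0.07 log units; within the scatter). Compound 4 `CC1(C)[C@H]2CC[C@]1(C)N(Cc1cn(-c3cccc(Br)c3)nn1)C(=O)C2` differs from compound 3 by bromo in place of hydroxy on an aromatic carbon, 3-hydroxyphenyl to 3-bromophenyl. The aryl variations measured so far, a 1.4-fold higher number from compound 1 to compound 2 (0.16 log units; within the scatter) included, moved nothing beyond the scatter, so no step beyond the scatter is expected in this assay: a 1.1-fold higher number from compound 3 to compound 4 (0.03 log units; within the scatter). Compound 4 is therefore estimated at 300 nM, range 120 nM to 750 nM.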

Compound 4, half-maximal inhibitory concentration: 90 nM
Compound 4: middle estimate off by 3.3-fold (0.52 log units), on the high side; measured number outside the range, below it.
By their numbers in this assay, from the lowest: compound 4; then compounds 1, 3 and 2 (each within the scatter of the next).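

In this assay, the aryl group on the aromatic nitrogen gives its first steps beyond the scatter with compound 4: bromo in place of hydroxy on an aromatic carbon (a 3.1-fold lower number from compound 3 to compound 4 (0.49 log units; beyond the scatter)), and 3-bromophenyl in place of the other aryl groups (a 2.6-fold lower number from compound 1 to compound 4 (0.41 log units; beyond the scatter); a 3.7-fold lower number from compound 2 to compound 4 (0.56 log units; beyond the scatter)). This place in the series therefore does respond to its substituent, which the hydroxy and methoxy compounds, all within the scatter of one another, did not show. Nothing available explains the difference between bromo and hydroxy.

As far as these compounds go, it remains open whether the lower number belongs to bromo specifically or would also come with other replacements of hydroxy. Chloro, an amine or a carboxylic acid on the same aromatic carbon would help to separate these possibilities.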